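The source may hold more compounds than are shown below. What is called first, only, known or untested is meant among the compounds shown, and "the series" means these compounds.

All of these compounds were tested in a functional assay on MDA-MB-231 cells (Homo sapiens) for antiproliferative activity, read by MTT assay, with a stated time of 24 h; a lower number here means a stronger inhibitor, a higher number a weaker inhibitor. There, compound 1 `O=C(NNc1cccc(Cl)c1)c1ccccc1NS(=O)(=O)c1cnc(O)nc1O` gives 11800 nM. Compound 2 `O=C(NNC(=O)c1cccc(Cl)c1)c1ccc(NS(=O)(=O)c2cnc(O)nc2O)cc1` gives 4160 nM, a lower number, and the gap between the two lies beyond the usual scatter. Compound 1 therefore holds the higher of the two actual numbers. Compound 3 `O=C(NNC(=O)c1ccccc1F)c1cccc(NS(=O)(=O)c2cnc(O)nc2O)c1` returns only a limit, > 20000 nM.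

Compound 4 `O=C(NNC(=O)c1ccccc1NS(=O)(=O)c1cnc(O)nc1O)c1ccccc1Cl` departs from compound 1 in one place, with (2-chlorophenyl)carbonyl in place of 3-chlorophenyl on an amine nitrogen. Compound 2 and compound 3 also carry a carbonyl on that nitrogen, but they offer no clear guide. Compound 2, at 4160 nM, reads lower than compound 1, whereas compound 3 gives no number to compare. Going by the values given here, no measured pair isolates this change, so no shift beyond the scatter is expected in this assay. The estimated change is a 1.3-fold lower number from compound 1 to compound 4 (0.12 log units; within the scatter). Compound 4 is expected to give 9000 nM, with an estimated range of 3000 nM to 25000 nM.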

Compound 4, half-maximal inhibitory concentration: 8310 nM
Compound 4: middle estimate off by 1.1-fold (0.03 log units), on the high side; measured number inside the range.
By their numbers in this assay, from the lowest: compounds 2, 4 and 1 (each within the scatter of the next, the first and the last beyond it). At a limit, above all of these: compound 3.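

Going by these compounds alone, the first one-place comparison in this assay is (2-chlorophenyl)carbonyl in place of 3-chlorophenyl on an amine nitrogen, and it gives a step that stays small (a 1.4-fold lower number from compound 1 to compound 4 (0.15 log units; within the scatter)). This position therefore accepts the larger group, with its carbonyl and added hydrogen-bond acceptor, without a shift beyond the scatter. Nothing measured here bears on why the step is this size.

The change alters both the link to the ring and the place of the chlorine, so the compounds shown cannot separate what each contributes. Nor do they show how 2-chlorophenyl attached directly to that nitrogen, or a small acetyl group there, would read in this assay.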